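A few compounds are considered here, and "the series" means these few. Any claim that something is new, unique, unknown or untested is made for them only; others in the source may bear on it.

Working notes on the series. Among the compounds with values here, compound 3 `O=c1c2ccccc2[se]n1-c1nnc(-c2ccccc2Br)s1` gives 12700 nM in a functional assay on A549 cells (Homo sapiens) for antiproliferative activity, read by CCK-8 assay, with a stated time of 48 h (a lower number here means a stronger inhibitor, a higher number a weaker inhibitor), the highest of the three numbers measured so far, though the margins are small: compound 1 `O=c1c2ccccc2[se]n1-c1nnc(-c2ccc(Cl)cc2)s1` gives 10400 nM and compound 2 `O=c1c2ccccc2[se]n1-c1nnc(-c2ccccc2Cl)s1` gives 10100 nM, and the steps of a 1.2-fold higher number from compound 1 to compound 3 (0.09 log units; within the scatter) and a 1.3-fold higher number from compound 2 to compound 3 (0.10 log units; within the scatter) both sit within the scatter, so no order among the three can be read.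

The next compound, compound 4 `O=c1c2ccccc2[se]n1-c1nnc(-c2ccccc2[N+](=O)[O-])s1`, differs from compound 3 by nitro in place of bromo on an aromatic carbon. Within the data shown here, two measured steps bear on it. The halogen exchange on the same aromatic carbon, a 1.3-fold higher number from compound 2 to compound 3 (0.10 log units; within the scatter), was within the scatter; moving a chloro across the ring, a 1.0-fold lower number from compound 1 to compound 2 (0.01 log units; within the scatter), was likewise within the scatter. Among the measured compounds shown here, no measured compound carries a nitro group, so the size of this particular change is untested here. On the evidence of the steps seen, the expectation for this assay is no step beyond the scatter, a 1.2-fold lower number from compound 3 to compound 4 (0.06 log units; within the scatter). Compound 4 is therefore estimated at 11000 nM, with a range from 5500 nM to 22000 nM.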

Compound 4, half-maximal inhibitory concentration: 11400 nM
Beside the measured number, compound 4's estimate is 1.0-fold (0.02 log units) below it; measured number inside the range.
By their numbers in this assay, from the lowest: compounds 2, 1, 4 and 3 (each within the scatter of the next).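

In this assay, on this aromatic carbon ortho to a large group, nitro takes the place of a halogen with no step beyond the scatter, either against bromo, a 1.1-fold lower number from compound 3 to compound 4 (0.05 log units; within the scatter), or against chloro, a 1.1-fold higher number from compound 2 to compound 4 (0.05 log units; within the scatter). The earlier steps shown here exchanged only one halogen for another or shifted chloro around the ring, whereas nitro brings more heavy atoms than bromo and hydrogen-bond acceptors that bromo lacks, and the number still stays within the scatter. No measurement is available that would explain why the four numbers lie so close together.

Going by these compounds, it remains open whether any group on this carbon, such as an amine, a carboxylic acid or a longer chain, would give a step beyond the scatter. The compounds shown also leave open whether a change to the shared core would do so, since all four carry it unchanged.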